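Swapping an Ethyl for a Much Larger Group

This account rests on a few compounds, and the source may have more. Where it says the series, first, only, none or still open, it means among the compounds named here.

In a functional assay (aorta) for inhibition, with Oryctolagus cuniculus as the target (a lower number here means a stronger inhibitor, a higher number a weaker inhibitor), compound 1 `CCOC(=O)N1C(=S)N=C(C)/C(=C(/O)OCC)C1c1cccc([N+](=O)[O-])c1` gives 17 nM, while compound 2 `CCOC(=O)N1C(=S)N=C(C)/C(=C(/O)OCC)C1c1ccccc1C(F)(F)F` gives 41 nM, the higher of the two numbers by a gap beyond the scatter. Compound 3 `CCO/C(O)=C1\C(C)=NC(=S)N(C(=O)O[C@H]2CCN(Cc3ccccc3)C2)C1c1ccccc1C(F)(F)F` changes compound 2 in one place, on an oxygen next to a carbonyl group, where the ethyl gives way to a far larger group with two rings: a group of 12 heavy atoms (11 carbon, 1 nitrogen; one five-membered non-aromatic ring with 1 hetero atom, one six-membered aromatic ring of carbon only) in place of a group of 2 heavy atoms (2 carbon; no ring), on an oxygen next to a carbonyl group. Among the compounds with values here, no measured pair shows a change of this kind, so any forecast is loose. A modest shift toward stronger inhibition is expected, with the estimated step being a 2.1-fold lower number from compound 2 to compound 3 (0.31 log units; beyond the scatter). For compound 3 the estimated value is 20 nM, within a range of 4 nM to 100 nM.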

Compound 3, half-maximal inhibitory concentration: 2 nM
Beside the measured number, compound 3's estimate is 10-fold (1.00 log units) above it; measured number below the stated range.
By their numbers in this assay, from the lowest: compound 3; then compound 1; then compound 2.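

Replacing the ethyl with the far larger two-ring group, on an oxygen next to a carbonyl group, gives a 21-fold lower number from compound 2 to compound 3 (1.31 log units; beyond the scatter) in this assay. This position therefore accepts much more than a small chain, and here the larger group brings a large gain in inhibition. Nothing available explains this gain.

Going by these compounds, it remains open which part of the new group matters: a simple benzyl group or the five-membered ring carrying only a methyl would help separate them. On these data alone, the opposite form of the defined stereocentre also remains open.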